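The source may hold more compounds than are shown below. What is called first, only, known or untested is meant among the compounds shown, and "the series" means these compounds.

Of the compounds shown here, two with the same shared core have been tested in a functional assay on HL-60 cells (Homo sapiens), read by MTT assay, with a stated time of 72 h; a higher number here means a weaker inhibitor of growth, a lower number a stronger inhibitor of growth. Compound 1 `Cc1ccc2c(O)cc(=O)[nH]c2c1` carries a methyl group on an aromatic carbon; in this assay compound 1 gives a limit of the assay, > 10000000 nM, rather than a number. Compound 2 `O=c1cc(O)c2ccc(C(F)(F)F)cc2[nH]1` carries a trifluoromethyl group at that position, and in this assay compound 2 gives 6200000 nM. The step from compound 1 to compound 2 is an at least 1.6-fold lower number from compound 1 to compound 2 (0.20 log units; that floor lies within the scatter); one of the two values shown is a limit, (the limit of > 10000000 nM in this assay, at which 1 of the 2 values shown sits), so the true size of that step is open. Among the two values shown, compound 2 holds the only actual number.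

Compound 3 `O=c1cc(O)c2ccc(F)cc2[nH]1` differs from compound 2 in one place: fluoro in place of trifluoromethyl on an aromatic carbon. Going by the values given here, only one measured step, that from compound 1 to compound 2, bears on this change, and it sets no more than a floor that lies within the scatter. The expected step from compound 2 to compound 3 in this assay is therefore a 1.3-fold higher number from compound 2 to compound 3 (0.11 log units; within the scatter), that is, no change beyond the scatter. For compound 3 the estimated value in this assay is 8000000 nM, expected to fall between 3000000 nM and 20000000 nM.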

Compound 3, concentration for 50% growth inhibition: > 10000000 nM
Compound 3 was reported as a limit; the forecaster's own chance of this, stated with the estimate: 40%; middle value at least 1.2-fold (0.09 log units) away from the limit.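

Compound 3, like compound 1, is reported in this assay only as a limit of the assay, so fluoro at this position, on an aromatic carbon meta to a fused ring and para to a fused ring, joins methyl in giving no actual number: the limit of > 10000000 nM in this assay, at which 2 of the 3 values shown sit. Replacing trifluoromethyl with fluoro gives an at least 1.6-fold higher number from compound 2 to compound 3 (0.20 log units; that floor lies within the scatter), which means the change may be small or large, since only its lower bound is known and that bound does not clear the usual scatter. The step between compound 1 and compound 3 cannot be read, and although compound 2 is now the only one of the three with an actual number, neither of its steps is printed as beyond the scatter, so this does not establish it as the strongest.

On these data alone, the true sizes of these steps remain open, as does the question of whether any change at this position can move the number clearly beyond the scatter. An amine, a carboxylic acid or a longer chain on this carbon would test whether the position tolerates groups quite unlike the three shown here.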